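Moving a Methyl Around the Benzyl Ring

The source may report more compounds than this note shows. Statements on the series, on what has been measured and on what is new or still open speak of the compounds shown alone.

Measured in an assay on isolated protein for displacement of a labelled ligand from D(4) dopamine receptor (Homo sapiens); a lower number here means a stronger inhibitor, a higher number a weaker inhibitor:
compound 1 `O=C(NC1CCN(Cc2cccc(C(F)(F)F)c2)CC1)c1ccc2ccccc2c1` gives 103 nM;
compound 2 `COc1cccc(CN2CCC(NC(=O)c3ccc4ccccc4c3)CC2)c1` gives 16 nM;
compound 3 `Cc1ccccc1CN1CCC(NC(=O)c2ccc3ccccc3c2)CC1` gives 26 nM.

Compound 3 stands second highest of these three numbers: a 1.6-fold higher number from compound 2 to compound 3 (0.21 log units; within the scatter) falls within the scatter, whereas a 4.0-fold lower number from compound 1 to compound 3 (0.60 log units; beyond the scatter) lies beyond it. Compound 4 `Cc1cccc(CN2CCC(NC(=O)c3ccc4ccccc4c3)CC2)c1` has the same atoms joined differently: 3-methylphenyl in place of 2-methylphenyl on a saturated chain carbon bound to an amine nitrogen in a ring. Every measured step alters this same place. Two are modest, a 6.4-fold lower number from compound 1 to compound 2 (0.81 log units; beyond the scatter) and a 4.0-fold lower number from compound 1 to compound 3 (0.60 log units; beyond the scatter), while a 1.6-fold higher number from compound 2 to compound 3 (0.21 log units; within the scatter) stays within the scatter. None moves a methyl alone, so only a small step in this assay is expected, with no clear direction. Compound 4 is therefore estimated at 22 nM, between 8 nM and 60 nM, which means an expected 1.2-fold lower number from compound 3 to compound 4 (0.07 log units; within the scatter).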

Compound 4, inhibition constant: 11 nM
Estimate against measurement, compound 4: 2.0-fold (0.30 log units) above, within the range that was stated.
By their numbers in this assay, from the lowest: compounds 4, 2 and 3 (each within the scatter of the next, the first and the last beyond it); then compound 1.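

Moving the methyl alone, from 2-methylbenzyl to 3-methylbenzyl (a 2.4-fold lower number from compound 3 to compound 4 (0.37 log units; beyond the scatter)), shows that in this assay its place on the ring can matter even though no atom is gained or lost. With the group in the same place, methyl and methoxy cannot be told apart (a 1.5-fold lower number from compound 2 to compound 4 (0.16 log units; within the scatter)), whereas replacing trifluoromethyl with methyl gives a larger step (a 9.4-fold lower number from compound 1 to compound 4 (0.97 log units; beyond the scatter)). Nothing available here explains these differences. Still open, on these data alone, is how a 4-methylphenyl group would compare with its 2-methylphenyl and 3-methylphenyl isomers. Also open, as far as these compounds go, is whether an amine or a chlorine on this ring would behave like methyl.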